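The source may hold more compounds than are shown below. What is called first, only, known or untested is meant among the compounds shown, and "the series" means these compounds.

In an ADME assay on HepG2 cells (Homo sapiens) for cytotoxicity, read by MTT assay, with a stated time of 72 h (on this read-out higher numbers stand for lower toxicity in this test and lower numbers for higher toxicity in this test), compound 3 `O=[N+]([O-])c1c(CS(=O)(=O)c2ccccc2)nc2c(-c3ccccc3CO)cc(Cl)cn12` gives 88000 nM, the higher of the two actual numbers, and compound 2 `O=[N+]([O-])c1c(CS(=O)(=O)c2ccccc2)nc2c(-c3ccc(CO)cc3)cc(Cl)cn12` gives 13100 nM. Compound 1 `N#Cc1ccc(-c2cc(Cl)cn3c([N+](=O)[O-])c(CS(=O)(=O)c4ccccc4)nc23)cc1` is reported only as a limit, > 3900 nM. Compound 4 `O=[N+]([O-])c1c(CS(=O)(=O)c2ccccc2)nc2c(-c3ccccc3C(F)(F)F)cc(Cl)cn12` differs from compound 3 by trifluoromethyl in place of hydroxymethyl on an aromatic carbon, ortho to a large group (trifluoromethyl in place of hydroxymethyl on an aromatic carbon). Neither a step that the limit leaves unreadable from compound 1 to compound 2 nor a step that the limit leaves unreadable from compound 1 to compound 3 can be sized. Within the data shown here, the one readable step, a 6.7-fold higher number from compound 2 to compound 3 (0.83 log units; beyond the scatter), is modest and also involves the hydroxymethyl group, so a modest step of similar size toward lower numbers is expected. The estimated change is a 4.9-fold lower number from compound 3 to compound 4 (0.69 log units; beyond the scatter). Compound 4 is expected at 18000 nM, within an estimated range of 4000 nM to 60000 nM.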

Compound 4, half-maximal cytotoxic concentration: 22700 nM
For compound 4 the middle estimate is 1.3-fold (0.10 log units) below the measured one, within the range that was stated.
By their numbers in this assay, from the lowest: compounds 2 and 4 (each within the scatter of the next); then compound 3.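

In this assay, the place of the group alone does not set the number: with the place kept, trifluoromethyl in place of hydroxymethyl gives a 3.9-fold lower number from compound 3 to compound 4 (0.59 log units; beyond the scatter). The other readable comparison, a 1.7-fold higher number from compound 2 to compound 4 (0.24 log units; within the scatter), shows that 2-(trifluoromethyl)phenyl and 4-(hydroxymethyl)phenyl cannot be told apart in this test. The step from compound 1 to compound 4 cannot be read: the limit of > 3900 nM in this assay, at which 1 of the 4 values shown sits. As far as these compounds go, it remains open whether an amine, a carboxylic acid or a longer chain ending in hydroxyl at this place would give a number nearer that of compound 3 or that of compound 4.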